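One more tetrazole on a simple amide

This account rests on a few compounds, and the source may have more. Where it says the series, first, only, none or still open, it means among the compounds named here.

In a functional assay on the whole organism with Rattus norvegicus as the target, at a dose of 25 mg/kg by the intravenous route (on this read-out higher numbers stand for an effect only at larger amounts of compound and lower numbers for an effect already at smaller amounts), compound 2 `O=C(Nc1ccccc1)c1ccc(-c2nn[nH]n2)cc1` has the highest number of the three measured compounds, at 8.4 mg/kg. Compound 1 `O=C(O)c1ccc(NC(=O)c2ccc(-c3nn[nH]n3)cc2)cc1` gives 2.3 mg/kg and compound 3 `O=C(Nc1ccc(-c2nn[nH]n2)cc1)c1cccc(-c2nn[nH]n2)c1` gives 0.05 mg/kg. Compound 4 `O=C(Nc1ccccc1-c1nn[nH]n1)c1ccc(-c2nn[nH]n2)cc1` differs from compound 2 by one change: 2H-tetrazol-5-yl in place of hydrogen on an aromatic carbon. Within the data shown here, the only measured step that bears on this is a 3.7-fold higher number from compound 1 to compound 2 (0.56 log units; beyond the scatter), where hydrogen replaces carboxy. Read in reverse, that modest step suggests a gain from adding a group to an aromatic carbon. Compound 3 also carries a second tetrazole, but neither it nor compound 1 has its added group ortho to a large group, so the size stays uncertain. A moderately lower number is expected: a 5.6-fold lower number from compound 2 to compound 4 (0.75 log units; beyond the scatter). For compound 4 the estimate is 1.5 mg/kg, with an expected range of 0.2 mg/kg to 8 mg/kg.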

Compound 4, dose for 50% inhibition: 1.5 mg/kg
Compound 4: middle estimate and measured number agree at the digits printed; measured number inside the range.
By their numbers in this assay, from the lowest: compound 3; then compounds 4 and 1 (each within the scatter of the next); then compound 2.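

In this assay, 2H-tetrazol-5-yl in place of hydrogen, ortho to a large group, brings a 5.6-fold lower number from compound 2 to compound 4 (0.75 log units; beyond the scatter) and so beyond the usual scatter. Among these compounds, the one earlier step took a carboxy group away from a different compound pair, whereas this step adds a group directly at this position. An effect at smaller amounts of compound is therefore compatible with a group of this size here.

Going by these compounds, whether an amine or a carboxylic acid at this same position would give a similar step stays open. Nothing measured here explains this step.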